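The source may hold more compounds than are shown below. What is called first, only, known or untested is meant among the compounds shown, and "the series" means these compounds.

In an ADME assay on MDCK cells (Canis lupus familiaris) for cytotoxicity, read by MTT assay, with a stated time of 24 h (on this read-out higher numbers stand for lower toxicity in this test and lower numbers for higher toxicity in this test), compound 1 (`O=[N+]([O-])c1ccc(S(=O)(=O)NCc2ccsc2)cc1`) gives 139000 nM while compound 2 (`O=S(=O)(NCc1csc2ccccc12)c1ccc(F)cc1`) gives 98600 nM and the two lie within the usual scatter of each other. Compound 3 (`O=[N+]([O-])c1ccc(S(=O)(=O)NCc2cc3ccccc3s2)cc1`) has no number here: its > 191000 nM is a limit of this assay and not a measured value. Compound 4 (`O=S(=O)(NCc1cc2ccccc2s1)c1ccc(Br)cc1`) follows from compound 3 with bromo in place of nitro on an aromatic carbon, para to a large group (bromo in place of nitro on an aromatic carbon). Among the compounds with values here, no measured pair isolates this change. The expectation therefore leans on compound 2, the one measured compound without a nitro, at 98600 nM in this assay on the shown numbers. The estimated change (an at least 1.5-fold lower number from compound 3 to compound 4 (0.20 log units; that floor lies within the scatter)) is expected to be small and toward lower numbers, possibly no larger than the scatter. For compound 4 the estimated value is 120000 nM with an expected range from 55000 nM to 250000 nM in this assay for this series.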

Compound 4, half-maximal cytotoxic concentration: > 174000 nM
Compound 4: no number, only a limit (the forecaster's own chance of this, stated with the estimate: 30%); at least 1.4-fold (0.16 log units) between middle value and limit.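

In this assay compound 3 gives > 191000 nM, which is a limit. Within the data shown here, compound 4 gives > 174000 nM, also a limit, so no step from compound 3 to compound 4 can be read. The compounds shown leave open how bromo in place of nitro on an aromatic carbon shifts the read-out.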